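A few compounds are considered here, and "the series" means these few. Any claim that something is new, unique, unknown or untested is made for them only; others in the source may bear on it.

Series notes. Compound 1 `CC(C)N(Cc1cccc(OCCCCCC(=O)O)c1)C(=O)c1ccc(-c2cccc(N(C)C)c2)cc1` and compound 2 `CC(C)N(Cc1cccc(OCCCCCC(=O)O)c1)C(=O)c1ccc(-c2c[nH]c3ccccc23)cc1` share one core and differ only in the group on an aromatic carbon of the outer ring. In an ADME assay on BJ cells (Homo sapiens) for cytotoxicity, read by CellTiter-Glo and resazurin assay, with a stated time of 72 h (on this read-out lower numbers stand for an effect already at smaller amounts and higher numbers for an effect only at larger amounts of compound), compound 1 gives > 26000 nM, which is a limit of the assay and not a number. In this assay compound 2 gives > 26000 nM, again a limit rather than a measured number. The step that the two limits leave unreadable from compound 1 to compound 2 hence cannot be sized. Both values sit at the limit of > 26000 nM in this assay, at which 2 of the 2 values shown sit. Compound 2 thus stands at the limit of this assay, with no number to place it against compound 1 beyond that.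

Compound 3 `COc1cc(F)cc(-c2ccc(C(=O)N(Cc3cccc(OCCCCCC(=O)O)c3)C(C)C)cc2)c1` is not yet measured. It differs from compound 2 by 3-fluoro-5-methoxyphenyl in place of 1H-indol-3-yl on an aromatic carbon. Within the data shown here, the one measured step in this assay is unreadable, so it gives no size to expect; it shows only that exchanging the group at this position has not brought either compound into the measured range. The step expected here is a step that the limit leaves unreadable from compound 2 to compound 3, with this assay expected once more to report a limit. The estimate for compound 3 is 40000 nM, with a range from 20000 nM to 120000 nM.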

Compound 3, half-maximal effective concentration: > 26000 nM
Compound 3: no number, only a limit (the forecaster's own chance of this, stated with the estimate: 80%); the middle value is on the limit's open side.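

No new step can be read. In this assay compound 3 gives > 26000 nM, a limit and not a number, so its steps from compound 1 and compound 2 cannot be read. The compounds shown leave open whether any group on this aromatic carbon gives a measured number, since all values sit at one limit: the limit of > 26000 nM in this assay, at which 3 of the 3 values shown sit.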